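A few compounds are considered here, and "the series" means these few. Any claim that something is new, unique, unknown or untested is made for them only; others in the source may bear on it.

Measured compounds:
compound 1, `Cc1nc(C)n2c(Nc3cc[nH]n3)nccc12`, 53000 nM in a functional assay for inhibition, with Homo sapiens as the target; a lower number here means a stronger inhibitor, a higher number a weaker inhibitor;
compound 2, `Cc1nc(C)n2c(S)nncc12`, for which this assay gives only a limit, > 48000 nM;
compound 3, `Cc1ncn2c(S)nncc12`, for which this assay likewise gives only a limit, > 48000 nM.

Compound 1 is the only one of the three with a number in this assay. Compound 2 and compound 3 differ by one change, (hydrogen in place of methyl on an aromatic carbon), and the step that the two limits leave unreadable from compound 2 to compound 3 cannot be read because of the limit of > 48000 nM in this assay, at which 2 of the 3 values shown sit. How the core of compound 1 differs from the core of compound 2 is not broken down here.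

Compound 4, `Cc1ncn2c(Nc3cc[nH]n3)nccc12`, has not been measured in this assay. It differs from compound 1 by hydrogen in place of methyl on an aromatic carbon, the same change that leads from compound 2 to compound 3. Going by the values given here, since that earlier step is unreadable, the expectation for compound 4 rests on compound 1 alone, whose value 53000 nM is the only number available. Compound 4 is therefore expected near 55000 nM, with a range from 20000 nM to 150000 nM. The step of a 1.0-fold higher number from compound 1 to compound 4 (0.02 log units; within the scatter) that this estimate means is expected to be small.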

Compound 4, half-maximal inhibitory concentration: 57000 nM
Estimate against measurement, compound 4: 1.0-fold (0.02 log units) below; measured number inside the range.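

In this assay, hydrogen in place of methyl on an aromatic carbon of the core of compound 1 gives a 1.1-fold higher number from compound 1 to compound 4 (0.03 log units; within the scatter), so on this core the change leaves the two compounds indistinguishable. The same change on the core of compound 2, which leads to compound 3, cannot be read, because both of those compounds give only a limit and not a number: the limit of > 48000 nM in this assay, at which 2 of the 4 values shown sit. The change therefore has one readable instance, which shows that it is tolerated on a single core but not that this result carries over to another core in this series.

From the compounds shown here alone, only hydrogen and methyl appear at this aromatic carbon, so it remains open whether a longer chain such as ethyl, or an amine, would give a number in this assay that lies beyond the scatter from compound 1. Going by these compounds, it also remains open whether the change would give a similarly small step on a core whose compounds both give numbers in this assay.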